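Compound 3 Without Its Pyrazole Ring

The source may hold more compounds than are shown below. What is called first, only, known or untested is meant among the compounds shown, and "the series" means these compounds.

Measured so far in a physicochemical assay for lipophilicity, at pH 7.4; on this read-out higher numbers stand for higher lipophilicity and lower numbers for lower lipophilicity:
- Compound 1 `Cc1cc(Cl)c(C(=O)NC(=O)Nc2nc3ccc(S(=O)(=O)C4CCN(C)CC4)cc3s2)cc1-n1cccn1`: 2.5
- Compound 2 `CN1CCC(S(=O)(=O)c2ccc3nc(NC(=O)NC(=O)c4cc(-n5cccn5)c(F)cc4Cl)sc3c2)CC1`: 2.4
- Compound 3 `CCOc1cc(Cl)c(C(=O)NC(=O)Nc2nc3ccc(CN4CCN(C)CC4)cc3s2)cc1-n1cccn1`: 3.8

Compound 3 has the highest of the three numbers, at 3.8. Its gap to compound 1 and to compound 2 lies well beyond the scatter. Those two compounds differ from compound 3 in more than one place, however, so their values cannot be tied to any single group.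

Compound 4 `CCOc1ccc(C(=O)NC(=O)Nc2nc3ccc(CN4CCN(C)CC4)cc3s2)c(Cl)c1` comes from compound 3 through one change, hydrogen in place of 1H-pyrazol-1-yl on an aromatic carbon. The rest of the molecule stays the same.

Within the data shown here, the only single-place step measured is a number 0.10 log units lower from compound 1 to compound 2 (within the scatter), for fluoro in place of methyl on an aromatic carbon. Among the measured compounds shown here, that step swaps one small group for another and offers only weak guidance, since no measured step removes a whole ring. The present change is larger, so a modest fall in this assay seems more likely than no movement, though this is a judgement with little direct support. The expected step is a number 0.40 log units lower from compound 3 to compound 4 (beyond the scatter). For compound 4 the estimated value is 3.4, with an expected range from 2.9 to 3.9.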

Compound 4, distribution coefficient: 3.4
For compound 4 middle estimate and measured number coincide at the digits printed, and the stated range covers the measured number.
By their numbers in this assay, from the lowest: compounds 2 and 1 (each within the scatter of the next); then compound 4; then compound 3.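

Putting hydrogen in place of 1H-pyrazol-1-yl on this aromatic carbon gives a number 0.40 log units lower from compound 3 to compound 4 (beyond the scatter) in this assay, a modest step. This is the first single-place step shown that removes a whole ring, the five-membered aromatic ring of 5 heavy atoms, and it shows that this change can move the number by more than the usual scatter, whereas the swap of fluoro for methyl gave a number 0.10 log units lower from compound 1 to compound 2 (within the scatter). No measurement at hand gives a reason for the size or direction of this step.

Going by these compounds, with only hydrogen and 1H-pyrazol-1-yl compared at the carbon ortho to the ethoxy group, it remains open whether the step belongs to this particular ring or would appear with any other group there, such as a phenyl ring, an amine or a carboxylic acid. On these data alone, it also remains open whether removing the same ring from compound 1 or compound 2, which differ from compound 3 in more than one place, would give a step of similar size.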